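Fluoro for ethyl on the difluoro carbon: clearance expected

The source may report more compounds than this note shows. Statements on the series, on what has been measured and on what is new or still open speak of the compounds shown alone.

Measured compounds:
compound 1 `Cc1cc(Nc2ccc(C(F)(F)F)cc2)n2nc(C3CC3)nc2n1` — 8.6 mL.min-1.g-1
compound 2 `CCC(F)(F)c1nc2nc(C)cc(Nc3ccc(S(F)(F)(F)(F)F)cc3)n2n1` — 6.7 mL.min-1.g-1

In an in vitro ADME assay on microsomes from liver (Mus musculus) for metabolic stability (a lower number here means slower removal, a higher number faster removal of the compound), compound 2 gives 6.7 mL.min-1.g-1, the lowest of the two numbers, and compound 1 gives 8.6 mL.min-1.g-1; the gap between compound 2 and compound 1 lies within the scatter, so neither can be called the more stable of the two.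

Compound 3 `Cc1cc(Nc2ccc(S(F)(F)(F)(F)F)cc2)n2nc(C(F)(F)F)nc2n1` has not been measured. It differs from compound 2 in one place: fluoro in place of ethyl on a saturated chain carbon bound to an aromatic carbon and two fluorine atoms. Cut one bond further out, the same difference reads 1,1-difluoropropyl to trifluoromethyl.

Among the compounds with values here, no step between measured compounds bears on this change, so the account rests on compound 2 alone. The expected step from compound 2 to compound 3 is a 1.2-fold lower number from compound 2 to compound 3 (0.09 log units; within the scatter), small and not beyond the scatter. Compound 3 is therefore estimated to give 5.5 mL.min-1.g-1 in this assay, with a range from 2.5 mL.min-1.g-1 to 11 mL.min-1.g-1.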

Compound 3, intrinsic clearance in microsomes: < 6 mL.min-1.g-1
Compound 3 was reported as a limit; the forecaster's own chance of this, stated with the estimate: 5%; the middle value is on the limit's open side.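

Within the data shown here, on the saturated chain carbon bound to an aromatic carbon and two fluorine atoms, fluoro in place of ethyl gives an at least 1.1-fold lower number from compound 2 to compound 3 (0.04 log units; that floor lies within the scatter) in this assay, the first step that can be read at this position. Losing the ethyl thus shows no sign of faster removal, although a floor within the scatter cannot show that removal has slowed. Going by these compounds, the value of compound 3, < 6 mL.min-1.g-1, is a limit, and the full size of the step stays unknown because the reading ends there: the limit of < 6 mL.min-1.g-1 in this assay, at which 1 of the 3 values shown sits.

The compounds shown leave open how an amine, a nitrile or a longer chain would fare in place of the fluoro on this carbon. Among these compounds, compound 1 differs from compound 3 in more than one place, so it offers no step to settle how this position behaves on another aniline substituent.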